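From 2-methylphenyl to 4-iodophenyl: a step not yet measured

A few compounds are considered here, and "the series" means these few. Any claim that something is new, unique, unknown or untested is made for them only; others in the source may bear on it.

Measured in a physicochemical assay for solubility, read by spectrophotometry, in phosphate buffer, with a stated time of 18 h, at pH 7.4; on this read-out lower numbers stand for lower solubility and higher numbers for higher solubility:
- compound 1 `CCc1ccc(-c2nc3c(c(C)nn3-c3ccccc3)c(-c3ccccc3Br)c2C#N)cc1`: 1500 nM
- compound 2 `CCc1ccc(-c2nc3c(c(C)nn3-c3ccccc3)c(-c3cccc(O)c3)c2C#N)cc1`: 18000 nM
- compound 3 `Cc1ccccc1-c1nc2c(c(C)nn2-c2ccccc2)c(-c2ccccc2O)c1C#N`: 21000 nM

Compound 3 at 21000 nM and compound 2 at 18000 nM lie within the scatter of each other, and both stand well clear of compound 1 at 1500 nM. Compound 4 `Cc1nn(-c2ccccc2)c2nc(-c3ccc(I)cc3)c(C#N)c(-c3ccccc3O)c12` has not yet been measured. It carries 4-iodophenyl in place of 2-methylphenyl on an aromatic carbon ortho to a cyano group: 4-iodophenyl in place of 2-methylphenyl on an aromatic carbon.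

Among the compounds with values here, only one measured step bears on this, and only indirectly. Within the data shown here, the large step of a 12-fold higher number from compound 1 to compound 2 (1.08 log units; beyond the scatter) replaces 2-bromophenyl at a different place, and no measured compound carries 4-iodophenyl. Among the measured compounds shown here, still, compound 1, the only measured compound with a halogen, gives 1500 nM, so a lower number is expected in this assay. The expected step is a 3.5-fold lower number from compound 3 to compound 4 (0.54 log units; beyond the scatter), a moderate one and quite uncertain. For compound 4 the estimate is 6000 nM, with an expected range of 1500 nM to 20000 nM.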

Compound 4, solubility: 1500 nM
Compound 4: the middle estimate sits 4.0-fold (0.60 log units) above what was measured; low and high end bracket the measured number.
By their numbers in this assay, from the lowest: compounds 1 and 4 (each within the scatter of the next); then compounds 2 and 3 (each within the scatter of the next).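

In this assay, within the data shown here, putting 4-iodophenyl in place of 2-methylphenyl on the aromatic carbon ortho to a cyano group gives a 14-fold lower number from compound 3 to compound 4 (1.15 log units; beyond the scatter), the first measured step at this position, and it is large. The two groups have the same heavy-atom count and the same hydrogen-bond donor and acceptor counts, and each is one six-membered aromatic ring of carbon only, so those counts do not separate them, yet the step lies beyond the scatter. Nothing measured here explains the step.

The compounds shown leave open whether the iodine or its place on the ring matters more, since this one change alters both the substituent and where it sits. A 4-methylphenyl or 2-iodophenyl group here would separate the two, and an aminophenyl group or a carboxylic acid would extend the comparison to other kinds of group.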